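Ester variation on the shared core: cytotoxicity notes

The source may report more compounds than this note shows. Statements on the series, on what has been measured and on what is new or still open speak of the compounds shown alone.

- compound 1 `CCCC(=O)Oc1c(C(C)C)cc2c3c1OC(=O)[C@@]31CCCC(C)(C)[C@@H]1CC2`: 99500 nM
- compound 2 `CC(C)c1cc2c3c(c1OC(=O)c1ccccc1)OC(=O)[C@@]31CCCC(C)(C)[C@@H]1CC2`: 503000 nM

In an ADME assay on AGS cells (Homo sapiens) for cytotoxicity, read by neutral red uptake, with a stated time of 24 h (on this read-out lower numbers stand for stronger inhibition and higher numbers for weaker inhibition), compound 2 has the higher of the two numbers, at 503000 nM. Compound 3 `CC(C)c1cc2c3c(c1OC(=O)CCCc1c[nH]c4ccccc14)OC(=O)[C@@]31CCCC(C)(C)[C@@H]1CC2` has 3-(1H-indol-3-yl)propyl in place of phenyl on a carbonyl carbon. For the measured compounds named here, the only measured step at this place is a 5.1-fold higher number from compound 1 to compound 2 (0.70 log units; beyond the scatter), with phenyl in place of propyl. Going by the values given here, no measured compound carries an indole, so compound 1, at 99500 nM, is the nearest guide, as its group also has a propyl chain. A modest step towards a lower number is expected: a 3.0-fold lower number from compound 2 to compound 3 (0.47 log units; beyond the scatter). The estimate for compound 3 is 170000 nM (expected range 60000 nM to 480000 nM).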

Compound 3, half-maximal inhibitory concentration: 46800 nM
For compound 3 the middle estimate is 3.6-fold (0.56 log units) above the measured one, outside the stated range (below it).
By their numbers in this assay, from the lowest: compound 3; then compound 1; then compound 2.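

At this place on a carbonyl carbon, the step with 3-(1H-indol-3-yl)propyl is large: an 11-fold lower number from compound 2 to compound 3 (1.03 log units; beyond the scatter), so the bigger group does not carry the number upward as phenyl did. The chain itself also tolerates substitution, since adding the indole gives a 2.1-fold lower number from compound 1 to compound 3 (0.33 log units; beyond the scatter), a modest step beyond the scatter. Nothing at hand accounts for either step.

As far as these compounds go, whether the lower number belongs to the indole itself stays open, as a phenyl or an amine at the end of the propyl chain would be needed to tell. The effect of a longer chain carrying the indole is also unknown.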